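Enlarging the Amide Substituent of Compound 1: Expected Solubility

A few compounds are considered here, and "the series" means these few. Any claim that something is new, unique, unknown or untested is made for them only; others in the source may bear on it.

This account concerns a small set of compounds sharing one core and measured in a physicochemical assay for solubility; a higher number here means a more soluble compound, a lower number a less soluble compound. Compound 1 has the structure `CNC(=O)c1cc(C(=O)NC2CC2)cc2c1OC[C@@]2(C)c1ccccc1`. In this assay compound 1 reaches only a limit of the assay, reported as >= 138 ug/mL, so no exact number is known for it. Compound 2, `CNC(=O)c1cc(C(=O)N[C@H]2C[C@@H]2C)cc2c1OC[C@@]2(CO)c1ccccc1`, likewise gives only a limit in this assay, namely >= 229 ug/mL. Compound 3, `CNC(=O)c1cc(C(N)=O)cc2c1OC[C@H]2c1ccccc1`, also sits at a limit in this assay, reported as >= 144 ug/mL. Since every value shown is a limit, compound 1 cannot be ranked against compound 2 or compound 3; all three simply sit at or beyond the reporting boundary, as the lines (the limit of >= 138 ug/mL in this assay, at which 1 of the 3 values shown sits), the limit of >= 144 ug/mL in this assay, at which 1 of the 3 values shown sits, and the limit of >= 229 ug/mL in this assay, at which 1 of the 3 values shown sits, show.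

Compound 4, `CNC(=O)c1cc(C(=O)N[C@H]2[C@@H]3C[C@@H](O)C[C@@H]32)cc2c1OC[C@@]2(C)c1ccccc1`, has not yet been measured. It differs from compound 1 in one place: a group of 7 heavy atoms (6 carbon, 1 oxygen; one three-membered non-aromatic ring of carbon only, one five-membered non-aromatic ring of carbon only) in place of a group of 3 heavy atoms (3 carbon; one three-membered non-aromatic ring of carbon only), on an amide-type nitrogen. Within the data shown here, no step between measured compounds is available to guide the size of this change, so the expectation must rest on compound 1 alone. Because compound 1 already sits at >= 138 ug/mL, compound 4 is expected to remain at or near that boundary, with a step that the limit leaves unreadable from compound 1 to compound 4 that is not expected to exceed the scatter. The estimate for compound 4 is therefore 150 ug/mL, within a range from 55 ug/mL to 400 ug/mL.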

Compound 4, solubility: >= 209 ug/mL
Compound 4: only a limit was reported; the forecaster's own chance of this, stated with the estimate: 60%; middle value at least 1.3-fold (0.14 log units) away from the limit.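

Among these compounds, compound 4 also gives only a limit in this assay, reported as >= 209 ug/mL, and compound 1 is likewise held at a limit, so no step from the cyclopropyl group to the larger group on the amide-type nitrogen can be read. The compounds shown leave open how soluble either compound actually is.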